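Trifluoromethylphenyl in Place of Chloromethoxyphenyl on the Shared Core

The compounds below may be only part of what the source reports. "The series", "measured", "known", "first", "only" and "open" are said of these compounds alone.

Compound 1, `CCCCC(Sc1ccc(OCCCOc2ccc(Cl)cc2OC)cc1)C(=O)O`, carries a 4-chloro-2-methoxyphenyl group at the end of its shared core. In an assay on isolated protein for inhibition of Polyunsaturated fatty acid 5-lipoxygenase (Homo sapiens), read by HPLC, with a stated time of 15 min, in the presence of a further agent that is not named here (a higher number here means a weaker inhibitor, a lower number a stronger inhibitor), compound 1 gives > 10000 nM, which is a limit of the assay rather than a number. Compound 3, `Cc1cccc(OCCCOc2ccc(CCC(=O)O)cc2)c1C`, likewise gives > 10000 nM in this assay, again a limit. Both sit at the limit of > 10000 nM in this assay, at which 2 of the 3 values shown sit. Compound 2, `CCCCC(Sc1ccc(OCCCOc2ccc(-c3ccccc3)cc2)cc1)C(=O)O`, is the only one of the three with a measured number, giving 900 nM in this assay. Compound 4, `CCCCC(Sc1ccc(OCCCOc2cccc(C(F)(F)F)c2)cc1)C(=O)O`, has not yet been measured; it differs from compound 1 by 3-(trifluoromethyl)phenyl in place of 4-chloro-2-methoxyphenyl on an oxygen on a saturated carbon. Among the measured compounds shown here, no step between measured compounds matches this change, so its size cannot be read from the data. Compound 1 stands at a limit, so any measured number for compound 4 would already mean a step toward stronger inhibition, and the expected step is an at least 2.0-fold lower number from compound 1 to compound 4 (0.30 log units; that floor lies within the scatter). Compound 4 is estimated to give about 5000 nM in this assay, within a range from 1500 nM to 20000 nM.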

Compound 4, half-maximal inhibitory concentration: 1600 nM
For compound 4 the middle estimate is 3.1-fold (0.49 log units) above the measured one, within the range that was stated.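

Among the compounds shown here, the change gives the first readable step at this position: in this assay, exchanging this one group gives an at least 6.2-fold lower number from compound 1 to compound 4 (0.79 log units; beyond the scatter). The earlier compounds shown here offered no such step, and this one shows that exchanging this terminal group alone is enough to bring the shared core from a limit of the assay to a measured number. The size of the step is only a bound, because the value of compound 1 is a limit and not a number: the limit of > 10000 nM in this assay, at which 2 of the 4 values shown sit.

Since the whole group changes at once, the compounds shown do not separate the part played by the trifluoromethyl from that of the chlorine or the methoxy. They also leave open how a nitrile or an amine on the same phenyl ring would read.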